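The compounds below may be only part of what the source reports. "The series", "measured", "known", "first", "only" and "open" are said of these compounds alone.

In a functional assay (Nicotiana tabacum) (on this read-out higher numbers stand for weaker inhibition and lower numbers for stronger inhibition), the shared core has been read with three different groups on its ring nitrogen substituent. Compound 1 (`CCCCCNc1nc(SC)nc2ncccc12`) gives 650 nM with pentyl, compound 2 (`CSc1nc(NC2CC2)c2cccnc2n1`) gives 4900 nM with cyclopropyl, and compound 3 (`CSc1nc(NCC(C)C)c2cccnc2n1`) gives 540 nM with isobutyl. Compound 3 thus sits at the low end of the three numbers, level with compound 1, as a 1.2-fold lower number from compound 1 to compound 3 (0.08 log units; within the scatter) shows. Within the data shown here, compound 2 stands apart, with a 7.5-fold higher number from compound 1 to compound 2 (0.88 log units; beyond the scatter) and a 9.1-fold lower number from compound 2 to compound 3 (0.96 log units; beyond the scatter) as the only steps beyond the scatter.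

Compound 4 (`C=CCNc1nc(SC)nc2ncccc12`) differs from compound 3 by vinyl in place of isopropyl on a saturated chain carbon bound to a nitrogen on an aromatic ring and the same change reads as isobutyl to allyl. No group with a double bond has been read yet, so the bearing of the measured steps is indirect. Allyl remains an open chain, and the open chains of compound 1 and compound 3 stay level in a 1.2-fold lower number from compound 1 to compound 3 (0.08 log units; within the scatter) despite their different shapes. The smaller group that enters leaves room for some loss, and a 9.1-fold lower number from compound 2 to compound 3 (0.96 log units; beyond the scatter) sets the upper scale for such a loss. A modest rise in the number is therefore expected, smaller than that step, and the estimate is a 2.0-fold higher number from compound 3 to compound 4 (0.31 log units; beyond the scatter) in this series. Compound 4 is estimated at 1100 nM with an expected range of 400 nM to 3000 nM in this assay for now.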

Compound 4, half-maximal inhibitory concentration: 400 nM
For compound 4 the middle estimate is 2.8-fold (0.44 log units) above the measured one; the measured number falls inside the stated range.
By their numbers in this assay, from the lowest: compounds 4, 3 and 1 (each within the scatter of the next); then compound 2.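

Within this assay, replacing isopropyl with vinyl on a saturated chain carbon bound to a nitrogen on an aromatic ring brings in the first double bond outside aromatic rings and one heavy atom fewer, yet the result stays within the scatter (a 1.4-fold lower number from compound 3 to compound 4 (0.13 log units; within the scatter)). The comparison with the pentyl compound also stays within the scatter (a 1.6-fold lower number from compound 1 to compound 4 (0.21 log units; within the scatter)), so allyl, isobutyl and pentyl now form one level set of open chains, while cyclopropyl stands apart from allyl by a step graded large (a 12-fold lower number from compound 2 to compound 4 (1.09 log units; beyond the scatter)). No supporting measurement accompanies these numbers, so the separation of cyclopropyl from the three open chains remains unexplained.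

The compounds shown leave open how far this level set extends, for instance to an ethyl or a propargyl group or to a benzyl group on the same nitrogen. They also leave open whether the separation belongs to cyclopropyl alone or also applies to larger rings such as cyclopentyl and cyclohexyl.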